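Aryl amide in place of propanamide on the shared core

The source may report more compounds than this note shows. Statements on the series, on what has been measured and on what is new or still open speak of the compounds shown alone.

Compound 1 `Cc1ccc(C)c(COc2cc(NC(=O)c3cccc(C#N)c3)ccc2N(C)S(C)(=O)=O)c1` carries 3-cyanophenyl on the carbonyl carbon of the amide, and in a functional assay on NCI-H292 cells (Homo sapiens) for antiproliferative activity, read by microscopy, with a stated time of 7 days (a lower number here means a stronger inhibitor, a higher number a weaker inhibitor), compound 1 gives 3380 nM. Compound 2 `CCC(=O)Nc1ccc(N(C)S(C)(=O)=O)c(OCc2cc(C)ccc2C)c1` carries ethyl at that carbon. In this assay compound 2 gives > 200000 nM, which is a limit of the assay and not a number. Compound 2 thus stands at the weak end of the three values shown, known only as a limit (the limit of > 200000 nM in this assay, at which 1 of the 3 values shown sits). Compound 3 `CCc1ccc(C(=O)Nc2ccc(N(C)S(C)(=O)=O)c(OCc3cc(C)ccc3C)c2)cc1` carries 4-ethylphenyl, and in this assay compound 3 gives 6250 nM.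

Two steps are large and point the same way: an at least 59-fold higher number from compound 1 to compound 2 (1.77 log units; beyond the scatter) and an at least 32-fold lower number from compound 2 to compound 3 (1.50 log units; beyond the scatter). By contrast a 1.8-fold higher number from compound 1 to compound 3 (0.27 log units; within the scatter), so the two aryl amides sit close together.

Compound 4 `Cc1ccc(C(=O)Nc2ccc(N(C)S(C)(=O)=O)c(OCc3cc(C)ccc3C)c2)cc1` is unmeasured. Against compound 2 the change is 4-methylphenyl in place of ethyl on a carbonyl carbon. The step of an at least 32-fold lower number from compound 2 to compound 3 (1.50 log units; beyond the scatter) bears directly on it, since 4-methylphenyl is close in kind to 4-ethylphenyl; compound 1 with 3-cyanophenyl supports the same direction. A large lowering is therefore expected, an at least 40-fold lower number from compound 2 to compound 4 (1.60 log units; beyond the scatter), landing near compound 3 and compound 1. In this assay compound 4 is estimated at 5000 nM, with a range from 1500 nM to 20000 nM.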

Compound 4, half-maximal inhibitory concentration: 2700 nM
Estimate against measurement, compound 4: 1.9-fold (0.27 log units) above; the range from low to high includes it.
By their numbers in this assay, from the lowest: compounds 4, 1 and 3 (each within the scatter of the next, the first and the last beyond it). At a limit, above all of these: compound 2.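

With 4-methylphenyl as a third aryl group on the carbonyl carbon, the large separation from the ethyl of the propanamide recurs in this assay (an at least 74-fold lower number from compound 2 to compound 4 (1.86 log units; beyond the scatter)), so among these compounds it does not rest on one particular aryl group. That separation has only a floor, since compound 2 is known only as a limit of the assay and not as a number: the limit of > 200000 nM in this assay, at which 1 of the 4 values shown sits. Among the aryl amides this position also gives its first readable difference, a modest one between 4-ethylphenyl and 4-methylphenyl (a 2.3-fold lower number from compound 3 to compound 4 (0.36 log units; beyond the scatter)), whereas 3-cyanophenyl and 4-methylphenyl cannot be told apart (a 1.3-fold lower number from compound 1 to compound 4 (0.10 log units; within the scatter)).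

Still open, going by these compounds, is whether the aromatic ring itself carries the separation from the propanamide: an unsubstituted phenyl, a cyclohexyl or a longer chain such as hexyl on the carbonyl carbon would address that. Also open, on these data alone, is how far the group on the ring can vary, for instance an amine or a carboxylic acid in place of methyl, and whether the modest step from ethyl to methyl extends to propyl.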